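The source may report more compounds than this note shows. Statements on the series, on what has been measured and on what is new or still open speak of the compounds shown alone.

The series shares one core and varies only the substituent on the amine nitrogen. In a functional assay on MGC-803 cells (Homo sapiens) for inhibition, read by sulforhodamine B assay (on this read-out lower numbers stand for stronger inhibition and higher numbers for weaker inhibition), compound 1 `O=C1C=C(Nc2ccc(I)cc2)C(=O)c2c1nc1n2[C@H]2OC[C@@H](O)[C@H]2OC1` gives 1400 nM, compound 2 `Cc1ccc(NC2=CC(=O)c3nc4n(c3C2=O)[C@H]2OC[C@@H](O)[C@H]2OC4)cc1` gives 1420 nM and compound 3 `Cc1ccc(NC2=CC(=O)c3nc4n(c3C2=O)[C@H]2OC[C@@H](O)[C@H]2OC4)cc1C` gives 860 nM. Compound 3 has the lowest of the three numbers, yet its distance to each of the others is within the scatter: a 1.6-fold lower number from compound 1 to compound 3 (0.21 log units; within the scatter) and a 1.7-fold lower number from compound 2 to compound 3 (0.22 log units; within the scatter). The swap of the single aromatic substituent, a 1.0-fold higher number from compound 1 to compound 2 (0.01 log units; within the scatter), also stays within the scatter.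

Compound 4 `O=C1C=C(NCc2ccccc2)C(=O)c2c1nc1n2[C@H]2OC[C@@H](O)[C@H]2OC1` differs from compound 3 by benzyl in place of 3,4-dimethylphenyl on an amine nitrogen; cut one bond further out, the difference reads (3,4-dimethylphenyl)amino to benzylamino. None of the three measured steps places a carbon between the amine nitrogen and the aromatic ring; all three only exchange groups on that ring, and all three fall within the scatter. Among the measured compounds shown here, there is thus no direct precedent for this change, while the steps that exist show the amine substituent tolerating variation without a shift in this assay. The expectation for compound 4 is accordingly a step of a 1.7-fold higher number from compound 3 to compound 4 (0.24 log units; within the scatter), not clearly beyond the scatter, with the range widened for the lack of precedent. Compound 4 is estimated at 1500 nM, between 600 nM and 4000 nM.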

Compound 4, half-maximal inhibitory concentration: 2670 nM
Estimate against measurement, compound 4: 1.8-fold (0.25 log units) below; the range from low to high includes it.
By their numbers in this assay, from the lowest: compounds 3, 1, 2 and 4 (each within the scatter of the next, the first and the last beyond it).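

Benzyl in place of 3,4-dimethylphenyl on the amine nitrogen is the first change at this position in this assay to give a step beyond the scatter, a 3.1-fold higher number from compound 3 to compound 4 (0.49 log units; beyond the scatter), and that step is modest. The separation holds against only one partner, since a 1.9-fold higher number from compound 2 to compound 4 (0.27 log units; within the scatter) and a 1.9-fold higher number from compound 1 to compound 4 (0.28 log units; within the scatter) both stay within the scatter, so the benzyl group is set apart from the 3,4-dimethylphenyl group but not from the 4-methylphenyl or 4-iodophenyl groups. No measurement available here accounts for the size of this step.

The step to benzyl removes both methyl groups and also detaches the aromatic ring from direct attachment to the amine nitrogen, so the compounds shown cannot assign the step to either change, and a pair made up of unsubstituted phenyl and 3,4-dimethylbenzyl on that nitrogen would separate the two. Also open, as far as these compounds go, is how the position responds to a longer chain such as phenethyl, or to a group that carries no aromatic ring, such as a simple alkyl chain or a chain ending in a carboxylic acid.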